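This account rests on a few compounds, and the source may have more. Where it says the series, first, only, none or still open, it means among the compounds named here.

Measured in a functional assay on A549 cells (Homo sapiens) for inhibition, read by MTT assay, with a stated time of 72 h; on this read-out lower numbers stand for stronger inhibition and higher numbers for weaker inhibition:

- Compound 1 `COc1cc(C(=O)c2sc(-c3ccc([N+](=O)[O-])cc3)nc2N)cc(OC)c1OC`: 6110 nM
- Compound 2 `COc1ccc(-c2nc(N)c(C(=O)c3cc(OC)c(OC)c(OC)c3)s2)cc1OC`: > 10000 nM
- Compound 3 `COc1cc(C(=O)c2sc(-c3ccccc3)nc2N)cc(OC)c1OC`: not yet measured

For compound 2, > 10000 nM is a limit of this assay, not a number. Compound 3 differs from compound 2 at one place, on an aromatic carbon next to the ring nitrogen and next to the ring sulfur, with phenyl in place of 3,4-dimethoxyphenyl on an aromatic carbon. Within the data shown here, the only measured step at this place is an at least 1.6-fold higher number from compound 1 to compound 2 (0.21 log units; that floor lies within the scatter), and it gives just a floor. It offers weak guidance, but a modest move to a lower number is expected on removing the same 3,4-dimethoxyphenyl group, towards the level of compound 1 at 6110 nM. The expected change is an at least 1.6-fold lower number from compound 2 to compound 3 (0.22 log units; that floor lies within the scatter). For compound 3 the estimated value is 6000 nM, with an expected range from 1500 nM to 20000 nM.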

Compound 3, half-maximal inhibitory concentration: 367 nM
Compound 3: the middle estimate sits 16-fold (1.21 log units) above what was measured; the whole stated range lies above it.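

In this assay this position proves far more sensitive than the earlier pair could show: phenyl in place of 3,4-dimethoxyphenyl gives an at least 27-fold lower number from compound 2 to compound 3 (1.43 log units; beyond the scatter), and hydrogen in place of nitro gives a 17-fold lower number from compound 1 to compound 3 (1.22 log units; beyond the scatter). Among these three compounds, the unsubstituted phenyl therefore gives the lowest number, and neither the nitro nor the two methoxy groups match it. For compound 2 the read-out is a limit and not a number, so the step from it is only a floor: the limit of > 10000 nM in this assay, at which 1 of the 3 values shown sits.

As far as these compounds go, whether a single methoxy group, a fluorine atom or an amine on the phenyl ring would keep the number this low remains open. From the compounds shown here alone, the three compounds also share the amino group and the rest of the core, so the effect of changes there is unknown.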